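This account rests on a few compounds, and the source may have more. Where it says the series, first, only, none or still open, it means among the compounds named here.

Of the compounds shown here, three built on a shared core have been measured in a functional assay on PC-3 cells (Homo sapiens) for inhibition, read by MTT assay, with a stated time of 72 h; on this read-out lower numbers stand for stronger inhibition and higher numbers for weaker inhibition. Compound 1 `O=C(CSc1nc(Nc2ccccc2)c2ccccc2n1)Nc1ccccc1F` gives 12400 nM; compound 2 `O=C(CSc1nc(Nc2ccccc2)c2ccccc2n1)Nc1cccc(F)c1` gives 15600 nM; compound 3 `CCc1ccc(NC(=O)CSc2nc(Nc3ccccc3)c3ccccc3n2)cc1` gives 17900 nM. All three differ only in the aryl group on the amide-type nitrogen, and their numbers sit within the scatter of one another: the steps read a 1.3-fold higher number from compound 1 to compound 2 (0.10 log units; within the scatter), a 1.4-fold higher number from compound 1 to compound 3 (0.16 log units; within the scatter) and a 1.1-fold higher number from compound 2 to compound 3 (0.06 log units; within the scatter). Compound 1 thus stands among them with no separation that this assay can resolve.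

Compound 4 `O=C(CSc1nc(Nc2ccccc2)c2ccccc2n1)Nc1ccc(F)c(Cl)c1` differs from compound 1 in the same place: 3-chloro-4-fluorophenyl in place of 2-fluorophenyl on an amide-type nitrogen. Among the measured compounds shown here, each measured step at that position, whether to 3-fluorophenyl or to 4-ethylphenyl, left the number within the scatter, and nothing among the measured compounds points to a step beyond the scatter in either direction for a 3-chloro-4-fluorophenyl here. Compound 4 is therefore expected to give 13000 nM, with a range of 6500 nM to 26000 nM. The expected step is a 1.0-fold higher number from compound 1 to compound 4 (0.02 log units; within the scatter).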

Compound 4, half-maximal inhibitory concentration: 15500 nM
Compound 4: the middle estimate sits 1.2-fold (0.08 log units) below what was measured; measured number inside the range.
By their numbers in this assay, from the lowest: compounds 1, 4, 2 and 3 (each within the scatter of the next).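

In this assay, 3-chloro-4-fluorophenyl on the amide-type nitrogen brings chlorine into the series, yet compound 4 does not separate from any earlier compound (a 1.3-fold higher number from compound 1 to compound 4 (0.10 log units; within the scatter)) (a 1.0-fold lower number from compound 2 to compound 4 (0.00 log units; within the scatter)) (a 1.2-fold lower number from compound 3 to compound 4 (0.06 log units; within the scatter)). The range of aryl groups without a resolved step at this position now extends to one carrying both fluorine and chlorine, alongside 2-fluorophenyl, 3-fluorophenyl and 4-ethylphenyl. Nothing available explains this lack of separation.

As far as these compounds go, whether a carboxylic acid, an amine or a longer alkyl chain in place of the aryl group on the amide-type nitrogen would give a step beyond the scatter remains open. Also open, from the compounds shown here alone, is whether any change elsewhere on the shared core would move the number.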